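Swapping chloro for trifluoromethyl in compound 2

This account rests on a few compounds, and the source may have more. Where it says the series, first, only, none or still open, it means among the compounds named here.

Compound 1 `O=C(NCc1ccccc1)Oc1ccc(Cl)cc1C(=O)Nc1ccc(F)cc1`: 34200 nM
Compound 2 `O=C(NCc1ccccc1)Oc1ccc(Cl)cc1C(=O)Nc1ccc(Cl)cc1`: 6400 nM
Compound 3 `O=C(Nc1ccccc1)Oc1ccc(Cl)cc1C(=O)Nc1ccc(Cl)cc1`: 900 nM

In an ADME assay on HepG2 cells (Homo sapiens), read by MTT assay, with a stated time of 72 h, in the presence of a further agent that is not named here (a higher number here means a weaker inhibitor, a lower number a stronger inhibitor), compound 2 stands in the middle of these three numbers. Compound 4 `O=C(NCc1ccccc1)Oc1ccc(Cl)cc1C(=O)Nc1ccc(C(F)(F)F)cc1` has not been measured yet and differs from compound 2 in one place: trifluoromethyl in place of chloro on an aromatic carbon. In words, this is trifluoromethyl in place of chloro on an aromatic carbon. The most relevant measured change touches that same group: a 5.3-fold lower number from compound 1 to compound 2 (0.73 log units; beyond the scatter), with chloro in place of fluoro. The other change, a 7.1-fold lower number from compound 2 to compound 3 (0.85 log units; beyond the scatter), concerns the amide-type nitrogen and bears on this less directly. Among the measured compounds shown here, no measured compound carries trifluoromethyl, so only a modest move toward a lower number is expected in this assay. The expected change is a 1.6-fold lower number from compound 2 to compound 4 (0.20 log units; within the scatter). For compound 4, the estimated value is 4000 nM, with an expected range from 1300 nM to 13000 nM.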

Compound 4, half-maximal inhibitory concentration: 3000 nM
The estimate for compound 4 lay 1.3-fold (0.12 log units) above the measured number; the measured number falls inside the stated range.
By their numbers in this assay, from the lowest: compound 3; then compound 4; then compound 2; then compound 1.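

In this assay, trifluoromethyl in place of chloro on this aromatic carbon gives a 2.1-fold lower number from compound 2 to compound 4 (0.33 log units; beyond the scatter), so the number keeps falling past chloro at this position. Across the whole series at this place, fluoro to trifluoromethyl gives an 11-fold lower number from compound 1 to compound 4 (1.06 log units; beyond the scatter), which shows that this one position alone can shift the number substantially. Nothing available here explains this order of groups. On these data alone, whether an amine or a carboxylic acid at this place would lower the number further remains open. Also open, as far as these compounds go, is whether trifluoromethyl would give a similar step with phenyl on the amide-type nitrogen, as in compound 3.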